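Series notes: one trifluoromethyl removed from compound 2

This account rests on a few compounds, and the source may have more. Where it says the series, first, only, none or still open, it means among the compounds named here.

Compound 1 `O=C(Nc1cccc(-n2cc(-c3ccncc3)c(-c3cc(O)cc(Cl)c3)n2)c1)Nc1ccc(Cl)c(C(F)(F)F)c1` and compound 2 `COc1cc(Cl)cc(-c2nn(-c3cccc(NC(=O)Nc4cc(C(F)(F)F)cc(C(F)(F)F)c4)c3)cc2-c2ccncc2)c1` share one core. In a functional assay on HOP-62 cells (Homo sapiens) for inhibition, read by sulforhodamine B assay, with a stated time of 48 h, tested at 0.01 uM (on this read-out higher numbers stand for a weaker effect at the one concentration tested and lower numbers for a stronger effect), compound 1 gives 99%, and in this assay compound 2 gives 93%. Compound 2 holds the lower of the two numbers, its nearest neighbour being compound 1, and the gap between them lies within the scatter. Compound 3 `COc1cc(Cl)cc(-c2nn(-c3cccc(NC(=O)Nc4cccc(C(F)(F)F)c4)c3)cc2-c2ccncc2)c1` differs from compound 2 in one place: hydrogen in place of trifluoromethyl on an aromatic carbon. Among the measured compounds shown here, no step between measured compounds is known, and both measured values sit near the top of the scale, so the expected step is a number 2 percentage points higher from compound 2 to compound 3 (within the scatter), nothing beyond the scatter in either direction. Compound 3 is estimated at 95%, with a range from 84% to 104%.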

Compound 3, a percentage reported as activity, at one concentration (the size of the read-out at that concentration, not a potency): 96%
For compound 3 the middle estimate is 1 percentage points below the measured one; measured number inside the range.
By their numbers in this assay, from the lowest: compounds 2, 3 and 1 (each within the scatter of the next).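

Among the compounds shown here, the first one-place step is hydrogen in place of trifluoromethyl on this aromatic carbon, and in this assay it gives a number 3 percentage points higher from compound 2 to compound 3 (within the scatter) on a six-membered aromatic ring of carbon only. At this single concentration, the trifluoromethyl at this place therefore makes no readable difference, though with both numbers near the top of the scale, the read-out leaves little room to show one. No measurement on hand bears on this step.

From the compounds shown here alone, whether an amine or a carboxylic acid on this carbon would move the number beyond the scatter remains open. Also open, going by these compounds, is whether compound 2 and compound 3 would separate at a higher concentration.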